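Swapping fluoro for chloro on compound 1

The source may hold more compounds than are shown below. What is called first, only, known or untested is meant among the compounds shown, and "the series" means these compounds.

In a functional assay on U-373MG ATCC cells (Homo sapiens) for inhibition, read by MTT assay, with a stated time of 72 h (a lower number here means a stronger inhibitor, a higher number a weaker inhibitor), compound 1 (`CC1(C)CC(NC(=S)NCc2ccccc2)c2cc(F)ccc2O1`) gives 27000 nM, compound 2 (`CC1(C)CC(NC(=S)Nc2cccc(C#N)c2)c2cc(F)ccc2O1`) gives 30000 nM and compound 3 (`O=[N+]([O-])c1cccc(NC(=S)NCc2cccc(Cl)c2)c1`) gives 32000 nM. These three numbers lie within the usual scatter of one another, so compound 1 stands level with the other two. Compound 4 (`CC1(C)CC(NC(=S)NCc2ccccc2)c2cc(Cl)ccc2O1`) differs from compound 1 in one place, with chloro in place of fluoro on an aromatic carbon. Within the data shown here, no measured step covers this swap. Among the measured compounds shown here, the only step available, a 1.1-fold higher number from compound 1 to compound 2 (0.05 log units; within the scatter), changes a different part of the molecule and stays within the scatter. Nothing shown therefore points to a real shift in this assay, and the estimated step is a 1.1-fold lower number from compound 1 to compound 4 (0.03 log units; within the scatter). Compound 4 is expected at 25000 nM, with an estimated range from 12000 nM to 50000 nM.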

Compound 4, half-maximal inhibitory concentration: 64000 nM
Beside the measured number, compound 4's estimate is 2.6-fold (0.41 log units) below it; measured number outside the range, above it.
By their numbers in this assay, from the lowest: compounds 1, 2, 3 and 4 (each within the scatter of the next, the first and the last beyond it).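

In this assay the swap gives a 2.4-fold higher number from compound 1 to compound 4 (0.37 log units; beyond the scatter) on a single aromatic carbon, so this position responds to a change of just one atom, and chloro sits on the weaker side of fluoro. Among these compounds, the only earlier step, a 1.1-fold higher number from compound 1 to compound 2 (0.05 log units; within the scatter) at a different part of the molecule, showed no shift beyond the scatter. Nothing measured here bears on why the number rises.

Still open, as far as these compounds go, is how bromo or methoxy at this position would compare, and whether chloro in place of fluoro has a similar effect on compound 2.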